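Compound 3 to compound 4, a series at its limit

A few compounds are considered here, and "the series" means these few. Any claim that something is new, unique, unknown or untested is made for them only; others in the source may bear on it.

In a functional assay on HEK293 cells (Homo sapiens) for cytotoxicity (on this read-out higher numbers stand for lower toxicity in this test and lower numbers for higher toxicity in this test), compound 1 (`COc1ccc([C@H]2CC(=O)N(c3ccccc3)C2)cc1OC1CCCC1`) gives > 10000 nM, which is a limit. Compound 2 (`COc1ccc([C@H]2CC(=O)N(c3cccc(N(C)C)c3)C2)cc1OC1CCCC1`) gives > 10000 nM, also a limit. Compound 3 (`COc1ccc([C@H]2CC(=O)N(c3cccc(C(F)(F)F)c3)C2)cc1OC1CCCC1`) gives > 10000 nM, again a limit and not a number. Going by the values given here, the series so far therefore has one reading: the limit of > 10000 nM in this assay, at which 3 of the 3 values shown sit.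

The next change leads to compound 4 (`COc1ccc([C@H]2CC(=O)N(c3cccc(NCc4ccoc4)c3)C2)cc1OC1CCCC1`), with ((furan-3-yl)methyl)amino in place of trifluoromethyl on an aromatic carbon.

Among the compounds with values here, the steps that bear on this change are a step that the two limits leave unreadable from compound 1 to compound 2, a step that the two limits leave unreadable from compound 1 to compound 3 and a step that the two limits leave unreadable from compound 2 to compound 3. None of them has a size that can be carried over, and none points in a direction. Within the data shown here, the entering group also has no measured precedent. The working expectation is that compound 4 stays at the same limit in this assay, with no step beyond the scatter.

The expected change is a step that the limit leaves unreadable from compound 3 to compound 4. For compound 4 the estimate is 15000 nM, with an expected range of 5000 nM to 30000 nM.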

Compound 4, half-maximal cytotoxic concentration: > 10000 nM
Compound 4 ended at the assay's limit; the forecaster's own chance of this, stated with the estimate: 80%; the middle value does not contradict the limit.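

In this assay compound 4 gives > 10000 nM, a limit and not a number. Going by these compounds alone, no step to compound 4 from compound 1, compound 2 or compound 3 can therefore be read. The compounds shown leave open whether any of these substituents changes cytotoxicity, and at what concentration any of the four becomes cytotoxic: the limit of > 10000 nM in this assay, at which 4 of the 4 values shown sit.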